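A few compounds are considered here, and "the series" means these few. Any claim that something is new, unique, unknown or untested is made for them only; others in the source may bear on it.

Series notes. The three measured compounds share one core, given as `C#Cc1cccc(Nc2ncnc3cc(OC)c(OCCCCC(=O)Nc4ccc(S(N)(=O)=O)cc4)cc23)c1` for compound 1, `COc1ccc(Nc2ncnc3cc(OC)c(OCCCCC(=O)Nc4ccc(S(N)(=O)=O)cc4)cc23)cc1OC` for compound 2 and `COc1cc2ncnc(Nc3cc(F)c(F)c(F)c3)c2cc1OCCCCC(=O)Nc1ccc(S(N)(=O)=O)cc1` for compound 3; they differ only in the group carried on a nitrogen on an aromatic ring. In a functional assay on NCI-H1975 cells (Homo sapiens) for antiproliferative activity, read by MTT assay, with a stated time of 72 h (on this read-out lower numbers stand for stronger inhibition and higher numbers for weaker inhibition), compound 1 gives 18800 nM, compound 2 gives 9230 nM and compound 3 gives 20000 nM. Compound 1 thus stands second highest of the three numbers: the step to compound 3 is a 1.1-fold higher number from compound 1 to compound 3 (0.03 log units; within the scatter), within the scatter, while the step to compound 2 is a 2.0-fold lower number from compound 1 to compound 2 (0.31 log units; beyond the scatter).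

Compound 4, `COc1ccccc1Nc1ncnc2cc(OC)c(OCCCCC(=O)Nc3ccc(S(N)(=O)=O)cc3)cc12`, is not yet measured. It differs from compound 1 in one place: 2-methoxyphenyl in place of 3-ethynylphenyl on a nitrogen on an aromatic ring. Both measured steps from compound 1 bear on it, as each also exchanges the group on that nitrogen: a 2.0-fold lower number from compound 1 to compound 2 (0.31 log units; beyond the scatter) and a 1.1-fold higher number from compound 1 to compound 3 (0.03 log units; within the scatter). The 3,4-dimethoxyphenyl gave a modest gain, the 3,4,5-trifluorophenyl none beyond the scatter; the 2-methoxyphenyl is expected to land between these outcomes. The expectation for compound 4 is a step of a 1.3-fold lower number from compound 1 to compound 4 (0.13 log units; within the scatter), modest at most and toward a lower number, possibly none beyond the scatter. Compound 4 is therefore estimated at 14000 nM, with a range from 5000 nM to 40000 nM.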

Compound 4, half-maximal inhibitory concentration: 8030 nM
For compound 4 the middle estimate is 1.7-fold (0.24 log units) above the measured one, within the range that was stated.
By their numbers in this assay, from the lowest: compounds 4 and 2 (each within the scatter of the next); then compounds 1 and 3 (each within the scatter of the next).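

In this assay, the 2-methoxyphenyl on this nitrogen brings a modest gain over two groups (a 2.3-fold lower number from compound 1 to compound 4 (0.37 log units; beyond the scatter); a 2.5-fold lower number from compound 3 to compound 4 (0.40 log units; beyond the scatter)). Among these compounds, until now, the 3,4-dimethoxyphenyl was the only group on this nitrogen to stand apart from the others, and the new result shows that this is not confined to that group: the two methoxy-bearing rings cannot be told apart (a 1.1-fold lower number from compound 2 to compound 4 (0.06 log units; within the scatter)). Among these four compounds, both methoxy-bearing rings give lower numbers than the 3-ethynylphenyl and the 3,4,5-trifluorophenyl, no compound goes against this, and all the steps remain modest at most. No measurement at hand bears on the reason for this separation.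

The two methoxy-bearing rings differ both in how many methoxy groups they carry and in where these sit, so the compounds shown do not separate those two changes. On these data alone, it also remains open whether the gain belongs to the methoxy group itself or would persist with a hydroxyl, an ethoxy group or an amine on the phenyl ring in its place.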